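The source may hold more compounds than are shown below. What is called first, only, known or untested is meant among the compounds shown, and "the series" means these compounds.

Working notes on the series in a functional assay on HCT-116 cells (Homo sapiens) for antiproliferative activity, read by sulforhodamine B assay, with a stated time of 72 h; a lower number here means a stronger inhibitor, a higher number a weaker inhibitor. Compound 1 `CNC(=O)C[C@@H]1C[C@@H](c2ccc(Cl)c(Cl)c2)[C@H](NC(=O)c2cc(-c3c(Cl)cnn3C)c(Cl)o2)CN1` gives 450 nM, while compound 2 `Cn1ncc(Cl)c1-c1cc(C(=O)N[C@@H]2CN[C@H](CCN3CCC(O)CC3)C[C@H]2c2ccc(Cl)c(Cl)c2)oc1Cl` gives 13700 nM, the higher of the two numbers and so the weaker inhibitor of this pair. Next in view is compound 3 `Cn1ncc(Cl)c1-c1cc(C(=O)N[C@@H]2CN[C@H](CCCO)C[C@H]2c2ccc(Cl)c(Cl)c2)oc1Cl`, which keeps the core of compound 2 and differs in the side chain: hydroxymethyl in place of 4-hydroxypiperidin-1-yl on a saturated chain carbon, two bonds along the chain from a saturated ring carbon. Cut one bond further out, this reads 2-(4-hydroxypiperidin-1-yl)ethyl to 3-hydroxypropyl.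

Going by the values given here, only one measured step bears on this change: a 30-fold higher number from compound 1 to compound 2 (1.48 log units; beyond the scatter), a large rise that accompanied the arrival of the 4-hydroxypiperidin-1-yl group. Compound 3 loses that group, so a large move in the opposite direction, towards a lower number, is expected in this assay. Compound 1, at 450 nM, marks the likely region, but compound 3 lacks its methylcarbamoyl group, and no hydroxy-ended chain has been measured, so a full return is not assumed. The expected change is a 9.1-fold lower number from compound 2 to compound 3 (0.96 log units; beyond the scatter), beyond the scatter. For compound 3 the estimated value is 1500 nM, with an expected range of 450 nM to 5000 nM.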

Compound 3, half-maximal inhibitory concentration: 510 nM
Compound 3: middle estimate off by 2.9-fold (0.47 log units), on the high side; measured number inside the range.
By their numbers in this assay, from the lowest: compounds 1 and 3 (each within the scatter of the next); then compound 2.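

In this assay, the change from 2-(4-hydroxypiperidin-1-yl)ethyl to 3-hydroxypropyl gives a 27-fold lower number from compound 2 to compound 3 (1.43 log units; beyond the scatter), so the large difference now appears in a second comparison at this position, with the 4-hydroxypiperidin-1-yl group as the part that leaves. Methylcarbamoyl is also not required to reach this range: 2-hydroxyethyl in place of methylcarbamoyl on a saturated chain carbon bound to a saturated ring carbon gives a 1.1-fold higher number from compound 1 to compound 3 (0.05 log units; within the scatter), and the two side chains cannot be told apart in this assay. No supporting measurement is available to account for either step.

Going by these compounds, it remains open whether the hydroxy group of the 3-hydroxypropyl chain contributes at all, a question that a plain propyl chain or a carboxylic acid at the same place would address. On these data alone, it is also open whether the weaker result of compound 2 goes with the piperidine ring or with its amine nitrogen, which a simple open-chain dimethylamine on the same chain could separate, and how a longer hydroxyalkyl chain would compare.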